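The source may report more compounds than this note shows. Statements on the series, on what has been measured and on what is new or still open speak of the compounds shown alone.

Measured compounds in an assay on CHO cells for displacement of a labelled ligand from prostaglandin D2 receptor 2 (Homo sapiens), read by scintillation counting; on this read-out lower numbers stand for stronger inhibition and higher numbers for weaker inhibition:
- compound 1 `Cc1ccc(S(=O)(=O)N(C)CC(C)C)cc1C#Cc1cc(Cl)ccc1OCC(=O)O`: 4.2 nM
- compound 2 `O=C(O)COc1ccccc1C#Cc1ccccc1Cl`: 747 nM
- compound 3 `CCCS(=O)(=O)c1ccc(C)c(C#Cc2cc(Cl)ccc2OC(C)C(=O)O)c1`: 1.2 nM

Compound 1 stands second highest of the three numbers. Its nearest neighbour is compound 3, whose inhibition constant of 1.2 nM is lower by a margin beyond the usual scatter; furthest away is compound 2, whose value of 747 nM is much higher, also well beyond the scatter. Compound 2 lacks the sulfonyl group carried by compound 1 and compound 3, and it is by far the weakest binder shown.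

Compound 4 `Cc1ccc(S(C)(=O)=O)cc1C#Cc1cc(Cl)ccc1OCC(=O)O` has not yet been measured in this assay. It differs from compound 1 in one place: methyl in place of isobutyl(methyl)amino on a sulfonyl sulfur. For the measured compounds named here, no measured pair shows this change on its own, so the size of the step must be expected from the wider picture. Since the sulfonyl-bearing compounds 1 and 3 are both far stronger than compound 2, keeping the sulfonyl while shrinking the group on it is expected to cost little. The step of a 2.1-fold higher number from compound 1 to compound 4 (0.33 log units; beyond the scatter) is expected to be small and toward weaker binding, close to the scatter. Compound 4 is therefore expected to give about 9 nM, within a range of 3 nM to 35 nM.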

Compound 4, inhibition constant: 5 nM
Compound 4: middle estimate off by 1.8-fold (0.26 log units), on the high side; the measured number falls inside the stated range.
By their numbers in this assay, from the lowest: compound 3; then compounds 1 and 4 (each within the scatter of the next); then compound 2.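

In this assay, putting methyl in place of isobutyl(methyl)amino on a sulfonyl sulfur gives a 1.2-fold higher number from compound 1 to compound 4 (0.08 log units; within the scatter), so the two compounds cannot be told apart by this read-out. For the compounds shown here, at this position, then, the whole isobutyl(methyl)amino part can give way to a single methyl with no change beyond the scatter, something no earlier pair could show. Nothing measured here accounts for this match between the two compounds.

As far as these compounds go, it remains open what an unsubstituted amino group or a phenyl ring on the same sulfonyl sulfur would give in this assay. Compound 2 and compound 3 each differ from compound 4 in more than one place, so neither settles what the sulfonyl group itself contributes.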